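A few compounds are considered here, and "the series" means these few. Any claim that something is new, unique, unknown or untested is made for them only; others in the source may bear on it.

Compound 1 `Nc1cc(N)c2nc(-c3ccccc3)c(Sc3ccc(F)cc3)nc2c1`: 19100 nM
Compound 2 `CCOC(=O)[C@H](CCC(=O)O)NC(=O)c1ccc(CNc2nc3cc(N)cc(N)c3nc2-c2ccccc2)cc1`: 45700 nM

In a functional assay on NCI-H23 cells (Homo sapiens) for inhibition, read by sulforhodamine B assay, with a stated time of 48 h (on this read-out higher numbers stand for weaker inhibition of growth and lower numbers for stronger inhibition of growth), compound 1 gives the lowest of the two numbers; compound 2 gives a number higher by a gap beyond the usual scatter. Compound 3 `Nc1cc(N)c2nc(-c3ccccc3)c(NCc3ccc(F)cc3)nc2c1` differs from compound 1 in one place: (4-fluorobenzyl)amino in place of (4-fluorophenyl)sulfanyl on an aromatic carbon. Going by the values given here, no step between measured compounds matches this change, so the two measured values give no direct guide. The step from compound 1 to compound 3 is expected to stay small, as a 1.3-fold higher number from compound 1 to compound 3 (0.12 log units; within the scatter). Compound 3 is therefore estimated at 25000 nM, with a range from 8000 nM to 80000 nM.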

Compound 3, concentration for 50% growth inhibition: 2400 nM
The estimate for compound 3 lay 10-fold (1.02 log units) above the measured number; the whole stated range lies above it.
By their numbers in this assay, from the lowest: compound 3; then compound 1; then compound 2.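

Putting (4-fluorobenzyl)amino in place of (4-fluorophenyl)sulfanyl on this aromatic carbon, ortho to a phenyl group, gives an 8.0-fold lower number from compound 1 to compound 3 (0.90 log units; beyond the scatter) in this assay and shows that the group held here matters to this read-out. The change introduces a nitrogen, an extra carbon and a hydrogen-bond donor together, so the step cannot be assigned to any one of them. Nothing available accounts for the step.

As far as these compounds go, whether the nitrogen or the extra carbon carries the step remains open; (4-fluorophenyl)amino or (4-fluorobenzyl)sulfanyl here would separate them. From the compounds shown here alone, the part played by the fluorine also remains open, as does the effect of a longer chain, such as a 2-phenylethylamino group.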